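The source may report more compounds than this note shows. Statements on the series, on what has been measured and on what is new or still open speak of the compounds shown alone.

The compounds share one core. Compound 1 `C=C1CC[C@@H]2[C@](C)(CO)[C@H](O)CC[C@@]2(C)[C@@H]1CCC1C(=O)OC[C@H]1O` gives only a limit in a functional assay on BMMC cells (Mus musculus, strain C57BL/6) for inhibition, with stated times of 5 days and 48 h (on this read-out higher numbers stand for weaker inhibition and lower numbers for stronger inhibition), namely > 30000 nM. Among the measured compounds shown here, compound 2 `C=C1CC[C@@H]2[C@](C)(CNCc3ccc(Cl)cc3)[C@H](O)CC[C@@]2(C)[C@@H]1/C=C/C1=CCOC1=O` gives 420 nM in this assay, the lowest of the two numbers; compound 3 `C=C1CC[C@@H]2[C@](C)(CNCc3ccc4c(c3)CC=N4)[C@H](O)CC[C@@]2(C)[C@@H]1/C=C/C1=CCOC1=O` gives 550 nM, and the single measured step, a 1.3-fold higher number from compound 2 to compound 3 (0.12 log units; within the scatter), stays within the scatter. Compound 4 `C=C1CC[C@H]2[C@@](C)(CC[C@@H](O)[C@@]2(C)C(=O)NCc2ccccc2)[C@@H]1/C=C/C1=CCOC1=O` differs from compound 2 by benzylcarbamoyl in place of ((4-chlorobenzyl)amino)methyl on a saturated ring carbon. For the measured compounds named here, no measured step touches the amine itself, so this change is only loosely guided; the limit for compound 1 the limit of > 30000 nM in this assay, at which 1 of the 3 values shown sits, is the only other point of reference. Compound 4 is therefore expected to give a weaker result, the expected step being a 4.8-fold higher number from compound 2 to compound 4 (0.68 log units; beyond the scatter). The estimated value for compound 4 is 2000 nM, with a range from 500 nM to 15000 nM.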

Compound 4, half-maximal inhibitory concentration: 19400 nM
Estimate against measurement, compound 4: 9.7-fold (0.99 log units) below, and the stated range ends below it.
By their numbers in this assay, from the lowest: compounds 2 and 3 (each within the scatter of the next); then compound 4. At a limit, above all of these: compound 1.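

The change on this saturated ring carbon gives a 46-fold higher number from compound 2 to compound 4 (1.66 log units; beyond the scatter) in this assay, whereas the earlier exchange of the ring end of the side group gave only a 1.3-fold higher number from compound 2 to compound 3 (0.12 log units; within the scatter). So this position does not tolerate every group of similar size: benzylcarbamoyl has as many heavy atoms as ((4-chlorobenzyl)amino)methyl, yet the numbers lie far apart. Nothing given here explains this step.

Going by these compounds, the change removes the chlorine and brings in a carbonyl together, so their shares stay open. A 4-chlorobenzylcarbamoyl group would separate them.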